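The compounds below may be only part of what the source reports. "The series", "measured", "known", "first", "only" and "open" are said of these compounds alone.

Of the compounds shown here, three on a shared core have been measured in an assay on SH-EP1 cells for displacement of a labelled ligand from Neuronal acetylcholine receptor; alpha4/beta2 (Homo sapiens), read by scintillation counting; a higher number here means a weaker inhibitor, a lower number a stronger inhibitor. Compound 1 `O=C(C1CC1)N1CC2CC1CN2` gives 2800 nM. Compound 2 `O=C(C1CC=CC1)N1CC2CC(C1)N2` gives 51 nM. Compound 3 `O=C([C@@H]1C[C@@H]1F)N1CC2CC(C1)N2` gives 1.7 nM, the lowest of the three numbers; its gaps to compound 2, the nearest, and to compound 1, the furthest, both lie beyond the usual scatter. Compound 4 `C[C@H]1C[C@@H]1C(=O)N1CC2CC(C1)N2` has not yet been measured. It differs from compound 3 in one place: 2-methylcyclopropyl in place of 2-fluorocyclopropyl on a carbonyl carbon. Among the compounds with values here, the three measured compounds each carry a different ring at this position, so no earlier pair shows directly what swapping the fluorine for a methyl does. The expectation is a modest rise in this assay for compound 4, a step of a 3.5-fold higher number from compound 3 to compound 4 (0.55 log units; beyond the scatter) that sits near the edge of the scatter. Compound 4 is therefore estimated at 6 nM, with a range from 1.5 nM to 25 nM.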

Compound 4, inhibition constant: 17 nM
Compound 4: middle estimate off by 2.8-fold (0.45 log units), on the low side; the range from low to high includes it.
By their numbers in this assay, from the lowest: compound 3; then compound 4; then compound 2; then compound 1.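

In this assay, putting a methyl where compound 3 carries its fluorine gives a 10-fold higher number from compound 3 to compound 4 (1.00 log units; beyond the scatter), a step beyond the usual scatter. Within the data shown here, the cyclopropyl ring and the number of heavy atoms stay the same, so this position on the carbonyl carbon responds to a change of one substituent on the ring, which the earlier compounds, each with a different ring, could not show. Nothing shown here explains the size of this step. Still open, from the compounds shown here alone, is how a chlorine, a hydroxyl group or an amine in place of the fluorine would read.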